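Hepatocyte clearance notes: from compound 2 toward compound 3

This account rests on a few compounds, and the source may have more. Where it says the series, first, only, none or still open, it means among the compounds named here.

Compound 1 `CC(=O)N[C@@H]1CCC[C@H](C(=O)Nc2cc(-c3cnn4c3CCCC4)c(F)cn2)C1` gives 73 uL/min in an ADME assay on cells (Hepatocyte, Rattus norvegicus) for metabolic stability, using equilibrium dialysis; a higher number here means faster removal of the compound, a lower number slower removal. For the measured compounds named here, compound 2 `CC(=O)N[C@@H]1CCC[C@H](C(=O)Nc2cc(-c3cnn4c3CCCC4)c(Cl)cn2)C1` gives 46 uL/min in this assay, which stands as the lowest of the two numbers so far; the one measured step is a 1.6-fold lower number from compound 1 to compound 2 (0.20 log units; within the scatter), so the two values cannot be ordered with confidence. Compound 3 `CC(=O)N[C@@H]1CCC[C@H](C(=O)Nc2cc(-c3cnn(C)c3C)c(Cl)cn2)C1` is not yet measured in this assay. The change from compound 2 to compound 3 is a group of 7 heavy atoms (5 carbon, 2 nitrogen; one five-membered aromatic ring with 2 hetero atoms) in place of a group of 9 heavy atoms (7 carbon, 2 nitrogen; one five-membered aromatic ring with 2 hetero atoms, one six-membered non-aromatic ring with 1 hetero atom), on an aromatic carbon.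

Going by the values given here, the measured step of a 1.6-fold lower number from compound 1 to compound 2 (0.20 log units; within the scatter) concerns chloro in place of fluoro, a different position, and no measured step touches the exchange of the group of 9 heavy atoms for 1,5-dimethyl-1H-pyrazol-4-yl. With nothing to set a direction, the expected step of no change at the digits printed from compound 2 to compound 3 (within the scatter) is none beyond the scatter. Compound 3 is therefore estimated at 46 uL/min in this assay, with a range from 18 uL/min to 115 uL/min.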

Compound 3, intrinsic clearance in a liver preparation (reported as CLH), per the amount of preparation that the assay uses: 10 uL/min
Beside the measured number, compound 3's estimate is 4.6-fold (0.66 log units) above it, and the stated range ends above it.
By their numbers in this assay, from the lowest: compound 3; then compounds 2 and 1 (each within the scatter of the next).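

In this assay, for the compounds shown here, 1,5-dimethyl-1H-pyrazol-4-yl in place of the group of 9 heavy atoms gives a 4.6-fold lower number from compound 2 to compound 3 (0.66 log units; beyond the scatter), the first step in these notes beyond the scatter, so the place ortho to the chloro group responds where the chloro-for-fluoro exchange gave no readable step. The entering and leaving groups both hold a five-membered aromatic ring with 2 hetero atoms and match in hydrogen-bond donors and acceptors, so the counted differences are the loss of the six-membered non-aromatic ring and the smaller heavy-atom count. Nothing measured here bears on the cause of this step.

Open, going by these compounds, is whether the exchange gives a comparable step with fluoro in place of the chloro group. Also open, on these data alone, is how an ethyl in place of either methyl, or a morpholine at this place, would read.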